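Removing the amino from compound 2: expected flat step

This account rests on a few compounds, and the source may have more. Where it says the series, first, only, none or still open, it means among the compounds named here.

Compound 1 `C[C@H](Nc1ncnc2[nH]cnc12)c1nn(-c2cccnc2)c2cc(Cl)ccc12` and compound 2 `C[C@H](Nc1nc(N)nc2[nH]cnc12)c1nn(-c2cccnc2)c2cc(F)ccc12` have been run in a functional assay on Hep 3B2 cells (Homo sapiens) for inhibition, read by sulforhodamine B assay, with a stated time of 72 h, tested at 10 uM; on this read-out lower numbers stand for less inhibition and higher numbers for more inhibition at the one concentration tested (going by the name of the read-out). In this assay compound 1 gives 13% and compound 2 gives 14%. Compound 2 thus carries the higher of the two numbers, but the gap to compound 1 lies within the scatter, so the pair reads alike. Compound 3 `C[C@H](Nc1ncnc2[nH]cnc12)c1nn(-c2cccnc2)c2cc(F)ccc12` is not yet measured; it differs from compound 2 as follows: hydrogen in place of amino on an aromatic carbon. With both measured compounds at a low read-out, the step is expected to be a number 1 percentage points lower from compound 2 to compound 3 (within the scatter), nothing beyond the scatter in either direction. Compound 3 is therefore estimated at 13% in this assay, within the range 3% to 25%.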

Compound 3, a percentage reported as inhibition, at one concentration (the size of the read-out at that concentration, not a potency): 20%
Compound 3: the middle estimate sits 7 percentage points below what was measured, within the range that was stated.
By their numbers in this assay, from the lowest: compounds 1, 2 and 3 (each within the scatter of the next).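

In this assay, hydrogen in place of amino on an aromatic carbon, between two ring nitrogen atoms, gives a number 6 percentage points higher from compound 2 to compound 3 (within the scatter) and so leaves the read-out without a readable change at this position. Fluoro in place of chloro on an aromatic carbon gives a number 7 percentage points higher from compound 1 to compound 3 (within the scatter) and likewise reads flat, so neither single change separates these compounds. Nothing at hand explains either step. Open, as far as these compounds go, is whether a methyl or methylamino between the two ring nitrogen atoms would move the read-out beyond the scatter. The same holds for a bromo or nitrile in place of the fluoro.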